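This account rests on a few compounds, and the source may have more. Where it says the series, first, only, none or still open, it means among the compounds named here.

In a functional assay on the whole organism (strain Sprague-Dawley) for inhibition, with Rattus norvegicus as the target, with a stated time of 10 min (a higher number here means that more compound is needed for the effect, a lower number that less compound is needed), two compounds have been measured so far. Compound 1 `CCOC(=O)c1cnc(-c2ccccc2OCC(C)C)[nH]c1=O` gives 3 mg/kg and compound 2 `CCCCCOc1ccccc1-c1ncc(C(=O)OCC)c(=O)[nH]1` gives 2 mg/kg, so compound 2 stands level with compound 1 within the scatter. Still unmeasured, compound 3 `CCOC(=O)c1cnc(-c2ccccc2OCC2CC2)[nH]c1=O` differs from compound 2 in one place: cyclopropyl in place of butyl on a saturated chain carbon bound to an oxygen on an aromatic ring. In words, cyclopropyl stands in place of butyl on a saturated chain carbon bound to an oxygen on an aromatic ring, which cut one bond further out reads pentyloxy to cyclopropylmethoxy. Going by the values given here, the only measured step at this place is a 1.5-fold lower number from compound 1 to compound 2 (0.18 log units; within the scatter). It joins two open chains, and no ring has been measured here, so it bears only loosely on this change. No step beyond the scatter is therefore expected in this assay, and the expected step is a 1.3-fold higher number from compound 2 to compound 3 (0.10 log units; within the scatter). Compound 3 is estimated at 2.5 mg/kg, with an expected range of 1 mg/kg to 7 mg/kg.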

Compound 3, dose for 50% inhibition: 0.3 mg/kg
Compound 3: the middle estimate sits 8.3-fold (0.92 log units) above what was measured; measured number below the stated range.
By their numbers in this assay, from the lowest: compound 3; then compounds 2 and 1 (each within the scatter of the next).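

In this assay this position proves sensitive to the group on the saturated chain carbon bound to an oxygen on an aromatic ring: cyclopropyl in place of butyl gives a 6.7-fold lower number from compound 2 to compound 3 (0.82 log units; beyond the scatter), and cyclopropyl in place of isopropyl gives a 10-fold lower number from compound 1 to compound 3 (1.00 log units; beyond the scatter). The two open chains stand level within the scatter, so the separation appears only with the three-membered ring, and among these compounds the smaller count of heavy atoms in cyclopropyl against butyl does not by itself account for it. Nothing at hand explains this gain.

Going by these compounds, whether the gain is specific to cyclopropyl or extends to other rings, such as cyclobutyl or cyclopentyl, at the same place remains open. Also open, on these data alone, is whether it survives exchange of the ethyl ester on the shared core for a carboxylic acid or an amide.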